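Furan in place of chlorophenyl: cytotoxicity expected unchanged

The source may report more compounds than this note shows. Statements on the series, on what has been measured and on what is new or still open speak of the compounds shown alone.

Compound 1 `Cc1ccc(-c2cc(-c3ccccc3O)nc(N)n2)cc1`: in an ADME assay on MT4 cells (Homo sapiens) for cytotoxicity, read by MTT assay, with a stated time of 5 days (on this read-out higher numbers stand for lower toxicity in this test and lower numbers for higher toxicity in this test), compound 1 reaches only the limit > 128000 nM.
Compound 2 `Nc1nc(-c2ccc(F)cc2)cc(-c2ccccc2O)n1`: in this assay compound 2 gives 67500 nM.
Compound 3 `Nc1nc(-c2cccc(Cl)c2)cc(-c2ccccc2O)n1`: in this assay compound 3 reaches only the limit > 125000 nM.

Compound 3 therefore stands at a limit of this assay, not at a measured number. Compound 4 `Nc1nc(-c2ccco2)cc(-c2ccccc2O)n1` differs from it by furan-2-yl in place of 3-chlorophenyl on an aromatic carbon. The measured steps are all exchanges of the aryl group at this same carbon: an at least 1.8-fold lower number from compound 1 to compound 2 (0.27 log units; that floor lies within the scatter), an at least 1.8-fold higher number from compound 2 to compound 3 (0.26 log units; that floor lies within the scatter) and a step that the two limits leave unreadable from compound 1 to compound 3. None of them involves a furan, and where readable none exceeds the scatter. A step of an at least 1.2-fold lower number from compound 3 to compound 4 (0.09 log units; that floor lies within the scatter) is accordingly expected, with no change beyond the scatter. Compound 4 is estimated at 100000 nM, within a range from 40000 nM to 200000 nM, and may again register only as a limit.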

Compound 4, half-maximal cytotoxic concentration: > 125000 nM
Compound 4: a limit, no number; the forecaster's own chance of this, stated with the estimate: 55%; middle value at least 1.2-fold (0.09 log units) from the limit.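

Swapping the six-membered carbon ring for a five-membered ring with a hetero atom at this carbon, the first non-benzene group here, still gives no number in this assay, as compound 4 reaches only a limit: the limit of > 125000 nM in this assay, at which 2 of the 4 values shown sit.

Among these compounds, the one readable step is an at least 1.8-fold higher number from compound 2 to compound 4 (0.26 log units; that floor lies within the scatter). The two steps that join a limit to a limit cannot be read.

As far as these compounds go, it remains open whether a non-aromatic group at this carbon, such as an amine or a carboxylic acid, would give a measurable number in this assay. From the compounds shown here alone, how far the true values of the limit compounds lie from one another also stays unknown.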